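A few compounds are considered here, and "the series" means these few. Any claim that something is new, unique, unknown or untested is made for them only; others in the source may bear on it.

Three compounds built on one shared core have numbers in a functional assay on MIA PaCa-2 cells (Homo sapiens) for antiproliferative activity; on this read-out lower numbers stand for an effect already at smaller amounts and higher numbers for an effect only at larger amounts of compound. Compound 1 (`CCCNC(=O)c1cccc2c1cc(C)n2-c1nc2c(c(NCc3ccccc3)n1)CCCC2`) gives 608 nM, and compound 2 (`CC#CC(=O)Nc1cccc2c1cc(C)n2-c1nc2c(c(NCc3ccccc3)n1)CCCC2`) gives 436 nM. Compound 3 (`CCCC#CC(=O)Nc1cccc2c1cc(C)n2-c1nc2c(c(NCc3ccccc3)n1)CCCC2`) gives 1570 nM, the highest of the three numbers, and both of its gaps to the other two lie beyond the scatter.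

Compound 4 (`CCC(=O)Nc1cccc2c1cc(C)n2-c1nc2c(c(NCc3ccccc3)n1)CCCC2`) has not yet been measured. It departs from compound 3 on a carbonyl carbon, with ethyl in place of pent-1-yn-1-yl on a carbonyl carbon.

Going by the values given here, no measured step makes this exact change, but three bear on it. The closest is a 3.6-fold higher number from compound 2 to compound 3 (0.56 log units; beyond the scatter), where adding ethyl to the chain raised the number. The step of a 2.6-fold higher number from compound 1 to compound 3 (0.41 log units; beyond the scatter) points the same way, though it is smaller. The step of a 1.4-fold lower number from compound 1 to compound 2 (0.14 log units; within the scatter) shows two different groups, only one of which holds a triple bond, giving values within the scatter of each other. Losing the triple bond in compound 4 therefore gives no clear reason to expect a value far from those of compound 1 and compound 2.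

A modest fall in the number is expected, an estimated 2.9-fold lower number from compound 3 to compound 4 (0.46 log units; beyond the scatter). Compound 4 is estimated at 550 nM, with an expected range of 220 nM to 1350 nM.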

Compound 4, half-maximal effective concentration: 1010 nM
Compound 4: the middle estimate sits 1.8-fold (0.26 log units) below what was measured; measured number inside the range.
By their numbers in this assay, from the lowest: compounds 2, 1, 4 and 3 (each within the scatter of the next, the first and the last beyond it).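

In this assay, ethyl on this carbonyl carbon gives a 1.6-fold lower number from compound 3 to compound 4 (0.19 log units; within the scatter), so at this place the change from pent-1-yn-1-yl to ethyl stays within the scatter, even though it removes the triple bond and shortens the group. The shorter alkyne behaves differently: ethyl in place of prop-1-yn-1-yl gives a 2.3-fold higher number from compound 2 to compound 4 (0.36 log units; beyond the scatter), which lies beyond the scatter, so a triple bond at this position does not by itself set the number, and only prop-1-yn-1-yl among these groups stands apart from ethyl. The step of a 1.7-fold higher number from compound 1 to compound 4 (0.22 log units; within the scatter) stays within the scatter, and nothing given here explains any of these steps.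

The compounds shown leave open whether a saturated chain such as pentyl would sit with ethyl or elsewhere, so chain length and the triple bond remain unseparated on this carbonyl carbon. They also leave open how a chain ending in an amine or a carboxylic acid would read at this place in this assay.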